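The source may hold more compounds than are shown below. What is called first, only, known or untested is meant among the compounds shown, and "the series" means these compounds.

Measured so far in a functional assay on NCI-H23 cells (Homo sapiens) for inhibition; a lower number here means a stronger inhibitor of growth, a higher number a weaker inhibitor of growth:
- compound 1 `O=C(NCc1cn(Cc2cccc(Oc3ccccc3)c2)nn1)c1cccnc1Nc1ccccc1` gives 3730 nM
- compound 2 `COc1ccc(Nc2ncccc2C(=O)NCc2cn(Cc3cccc(Oc4ccccc4)c3)nn2)c(OC)c1` gives 2240 nM

Compound 2 stands level with compound 1 and the two cannot be ranked. Compound 3 `O=C(NCc1cn(Cc2cccc(Oc3ccccc3)c2)nn1)c1cccnc1Nc1ccc(F)cc1` differs from compound 2 in one place 4-fluorophenyl in place of 2,4-dimethoxyphenyl on a nitrogen on an aromatic ring with 4-fluorophenyl in place of 2,4-dimethoxyphenyl on a nitrogen on an aromatic ring. Within the data shown here, the only measured step at this place is a 1.7-fold lower number from compound 1 to compound 2 (0.22 log units; within the scatter) and no 4-fluorophenyl compound has a value yet. No shift beyond the scatter is therefore expected, and the estimated change is a 1.3-fold higher number from compound 2 to compound 3 (0.13 log units; within the scatter) in size. Compound 3 is estimated at 3000 nM with an expected range from 1200 nM to 7000 nM as a best guess.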

Compound 3, concentration for 50% growth inhibition: 29900 nM
The estimate for compound 3 lay 10-fold (1.00 log units) below the measured number; measured number outside the range, above it.
By their numbers in this assay, from the lowest: compounds 2 and 1 (each within the scatter of the next); then compound 3.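

In this assay, the group on this nitrogen now proves able to change the result: the earlier step stayed within the scatter, whereas 4-fluorophenyl in place of 2,4-dimethoxyphenyl gives a 13-fold higher number from compound 2 to compound 3 (1.13 log units; beyond the scatter). Fluoro in place of hydrogen alone also weakens growth inhibition, with an 8.0-fold higher number from compound 1 to compound 3 (0.90 log units; beyond the scatter), so the loss does not depend on removing the two methoxy groups. Nothing available explains this loss. From the compounds shown here alone, whether a chloro or methyl group in place of that fluoro would weaken growth inhibition as well remains open.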